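Swapping the aryl group on the pyrazoline ring

The source may report more compounds than this note shows. Statements on the series, on what has been measured and on what is new or still open speak of the compounds shown alone.

Compound 1 `Cc1cc(O)c(C2=NN(c3ccc(S(N)(=O)=O)cc3)C(c3ccccc3O)C2)cc1Cl`: 38600 nM
Compound 2 `Cc1cc(O)c(C2=NN(c3ccc(S(N)(=O)=O)cc3)C(/C=C/c3ccccc3)C2)cc1Cl`: 42700 nM

In a functional assay on SK-OV-3 cells (Homo sapiens) for antiproliferative activity, with a stated time of 48 h (on this read-out higher numbers stand for lower toxicity in this test and lower numbers for higher toxicity in this test), compound 2 gives 42700 nM, and compound 1 gives 38600 nM; the two lie within the scatter of each other. Compound 3 `COc1ccc(C2CC(c3cc(Cl)c(C)cc3O)=NN2c2ccc(S(N)(=O)=O)cc2)c(OC)c1OC` differs from compound 2 by 2,3,4-trimethoxyphenyl in place of 2-phenylethenyl on a saturated ring carbon. Going by the values given here, the only measured step at this position, a 1.1-fold higher number from compound 1 to compound 2 (0.04 log units; within the scatter), changed the number by less than the scatter, so a change of aryl group here has not so far shifted the read-out. Among the compounds with values here, since no step covers the trimethoxyphenyl group itself, the expectation for compound 3 is a number close to that of compound 2, estimated at 40000 nM (range 15000 nM to 100000 nM), a step of a 1.1-fold lower number from compound 2 to compound 3 (0.03 log units; within the scatter).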

Compound 3, concentration lethal to 50% of the cells: 54900 nM
The estimate for compound 3 lay 1.4-fold (0.14 log units) below the measured number; the range from low to high includes it.
By their numbers in this assay, from the lowest: compounds 1, 2 and 3 (each within the scatter of the next).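

In this assay, the 2,3,4-trimethoxyphenyl group, with its methoxy oxygens, gives a number that stays close to those of the two earlier groups: a 1.3-fold higher number from compound 2 to compound 3 (0.11 log units; within the scatter), and a 1.4-fold higher number from compound 1 to compound 3 (0.15 log units; within the scatter). So the lack of change at this saturated ring carbon now extends to a third aromatic group, one that carries hydrogen-bond acceptors. No measurement at hand explains this flat result. From the compounds shown here alone, all three groups contain a benzene ring, so it remains open whether an amine, a carboxylic acid or a longer alkyl chain here would shift the number.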